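Working notes: from compound 3 to compound 4

The compounds below may be only part of what the source reports. "The series", "measured", "known", "first", "only" and "open" are said of these compounds alone.

In a physicochemical assay for lipophilicity, using the shake flask method, measured as octanol-water partition, at pH 7.4 (on this read-out higher numbers stand for higher lipophilicity and lower numbers for lower lipophilicity), compound 1 `CC(=O)N[C@@H]1CCC[C@H](C(=O)Nc2cc(-c3cnc(C)n3C)c(Cl)cn2)C1` gives 2.2, compound 2 `CC(=O)N[C@@H]1CCC[C@H](C(=O)Nc2cc(-c3cnc4n3CCC4)c(Cl)cn2)C1` gives 2.6 and compound 3 `CC(=O)N[C@@H]1CCC[C@H](C(=O)Nc2cc(-c3cnn4c3NCCC4)c(Cl)cn2)C1` gives 2.4. Compound 3 cannot be separated from either of the others: one step is a number 0.20 log units higher from compound 1 to compound 3 (within the scatter), and the other is a number 0.20 log units lower from compound 2 to compound 3 (within the scatter).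

The change leading to compound 4 `CC(=O)N[C@@H]1CCC[C@H](C(=O)Nc2cc(-c3cnc4n3CC(C)(C)C4)c(Cl)cn2)C1` is a group of 10 heavy atoms (8 carbon, 2 nitrogen; one five-membered non-aromatic ring with 1 hetero atom, one five-membered aromatic ring with 2 hetero atoms) in place of a group of 9 heavy atoms (6 carbon, 3 nitrogen; one five-membered aromatic ring with 2 hetero atoms, one six-membered non-aromatic ring with 2 hetero atoms), on an aromatic carbon. The site is opposite the ring nitrogen and ortho to a chloro group. The entering group has 0 hydrogen-bond donors, and the leaving group has 1.

The most useful guide is a number 0.40 log units higher from compound 1 to compound 2 (beyond the scatter), as this step ends on the same pair of ring types that compound 4 carries. Going by the values given here, no measured step isolates the extra carbon atoms of the entering group, so the range is kept wide. A rise beyond the scatter is nevertheless expected in this assay. The expected step is a number 0.60 log units higher from compound 3 to compound 4 (beyond the scatter). The estimate for compound 4 is 3, with an expected range of 2.7 to 3.4.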

Compound 4, distribution coefficient: 3.6
Beside the measured number, compound 4's estimate is 0.60 log units below it; measured number above the stated range.
By their numbers in this assay, from the lowest: compounds 1, 3 and 2 (each within the scatter of the next, the first and the last beyond it); then compound 4.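

Working on the aromatic carbon opposite the ring nitrogen, this assay now covers a much wider span than the earlier compounds showed, with a number 1.40 log units higher from compound 1 to compound 4 (beyond the scatter) and a number 1.20 log units higher from compound 3 to compound 4 (beyond the scatter). Going by these compounds alone, the most direct reading is a number 1.00 log units higher from compound 2 to compound 4 (beyond the scatter): the leaving and entering groups have the same ring types, so this step goes with the extra carbon atoms on the five-membered non-aromatic ring, and it exceeds every step among the earlier compounds. No measurement at hand accounts for the size of this step.

On these data alone, it remains open whether a single methyl on that five-membered non-aromatic ring would give a step of part of this size or nearly all of it. A hydroxyl or an amine on the same ring, in place of the extra carbon atoms, is also untested in the compounds shown.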